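Acetamide to Trifluoroacetamide at a Shared Core

The source may report more compounds than this note shows. Statements on the series, on what has been measured and on what is new or still open speak of the compounds shown alone.

Measured compounds:
Compound 1 `CC(C)S(=O)(=O)Nc1cccc2c1CCCC2c1c[nH]cn1` — 1150 nM
Compound 2 `CC(=O)Nc1cccc2c1CCCC2c1c[nH]cn1` — 525 nM

Among the measured compounds shown here, in an assay on isolated protein for binding affinity to Alpha-1A adrenergic receptor (Rattus norvegicus), read by radioligand binding (a lower number here means a stronger inhibitor, a higher number a weaker inhibitor), compound 2 gives the lower of the two numbers; its only neighbour is compound 1, and the step of a 2.2-fold lower number from compound 1 to compound 2 (0.34 log units; beyond the scatter) is modest though beyond the scatter. Compound 3 `O=C(Nc1cccc2c1CCCC2c1c[nH]cn1)C(F)(F)F` differs from compound 2 by trifluoromethyl in place of methyl on a carbonyl carbon. For the measured compounds named here, no measured step alters the substituent on the carbonyl carbon itself. Going by the values given here, the single step that bears on the change, and only loosely, is the one replacing the whole group on the amide-type nitrogen, where the number moved by a 2.2-fold lower number from compound 1 to compound 2 (0.34 log units; beyond the scatter); that gives a sense of how much this region of the shared core has moved so far, and no more. With nothing closer to go on, the step from compound 2 to compound 3 is expected to stay within the scatter, a 1.1-fold higher number from compound 2 to compound 3 (0.06 log units; within the scatter), in either direction. Compound 3 is therefore estimated at 600 nM, with a range from 200 nM to 1800 nM.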

Compound 3, inhibition constant: 166 nM
Compound 3: middle estimate off by 3.6-fold (0.56 log units), on the high side; the measured number lies below the stated range.
By their numbers in this assay, from the lowest: compound 3; then compound 2; then compound 1.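

In this assay the substituent on the carbonyl carbon proves to count in its own right: trifluoromethyl in place of methyl gives a 3.2-fold lower number from compound 2 to compound 3 (0.50 log units; beyond the scatter) and so moves the number at least as far as the earlier exchange of the whole group on the nitrogen did. Measured against the isopropylsulfonyl group, the (trifluoromethyl)carbonyl group gives a 6.9-fold lower number from compound 1 to compound 3 (0.84 log units; beyond the scatter) and places compound 3 lowest of the three. Nothing given here accounts for why the number fell.

The compounds shown leave open whether difluoromethyl or a longer chain such as pentafluoroethyl on the carbonyl carbon would lower the number further or lose the gain. They also leave open whether trifluoromethyl in place of isopropyl on the sulfonyl group would produce a similar step.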